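Moving a methyl around the phenyl on the ring nitrogen

A few compounds are considered here, and "the series" means these few. Any claim that something is new, unique, unknown or untested is made for them only; others in the source may bear on it.

Of the compounds shown here, three sharing one core have been measured in an assay on Sf9 cells for inhibition of protein deacetylase HDAC6 (Homo sapiens), read by fluorescence, with a stated time of 40 min, tested at 100 nM; on this read-out lower numbers stand for less inhibition and higher numbers for more inhibition at the one concentration tested (going by the name of the read-out). Compound 1 `Cc1ccc(-n2nc(-c3ccccc3)nc2CNc2ccc(C(=O)NO)cc2)cc1` gives 60.7%, compound 2 `CC(C)c1ccc(-n2nc(-c3ccccc3)nc2CNc2ccc(C(=O)NO)cc2)cc1` gives 52.6%, and compound 3 `Cc1ccc(-n2nc(-c3ccccc3)nc2CNc2ccc(C(=O)NO)cc2)cc1C` gives 53%. Among these numbers compound 3 stands second highest; its nearest neighbour is compound 2, its furthest compound 1, and both gaps lie within the scatter. The steps to compound 3 were a number 7.7 percentage points lower from compound 1 to compound 3 (within the scatter) and a number 0.4 percentage points higher from compound 2 to compound 3 (within the scatter), while the step between the other two was a number 8.1 percentage points lower from compound 1 to compound 2 (within the scatter), so no change on this phenyl has yet moved this assay beyond the scatter.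

Compound 4 `Cc1cc(C)cc(-n2nc(-c3ccccc3)nc2CNc2ccc(C(=O)NO)cc2)c1` differs from compound 3 by 3,5-dimethylphenyl in place of 3,4-dimethylphenyl on an aromatic nitrogen. Among the compounds with values here, the steps that bear on it are those of compound 3 from compound 1 and from compound 2, both small, so the expected step is none beyond the scatter: in this assay compound 4 is expected to show no change at the digits printed from compound 3 to compound 4 (within the scatter). Compound 4 is therefore estimated at 53%, within a range of 40% to 66%.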

Compound 4, a percentage reported as inhibition, at one concentration (the size of the read-out at that concentration, not a potency): 49.8%
Estimate against measurement, compound 4: 3.2 percentage points above, and the stated range covers the measured number.
By their numbers in this assay, from the lowest: compounds 4, 2, 3 and 1 (each within the scatter of the next, the first and the last beyond it).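

In this assay, rearranging the two methyl groups on this phenyl gives a number 3.2 percentage points lower from compound 3 to compound 4 (within the scatter), and the exchange for the 4-isopropylphenyl group gives a number 2.8 percentage points lower from compound 2 to compound 4 (within the scatter), so 3,5-dimethylphenyl cannot be told apart from either of these groups on the ring nitrogen. Within the data shown here, the comparison with the single methyl, however, gives a number 10.9 percentage points lower from compound 1 to compound 4 (beyond the scatter), a modest step and the first change on this phenyl to pass the scatter, although compound 2 and compound 3 each remain within the scatter of compound 1. Nothing available explains why this one step stands out. As far as these compounds go, it remains open whether a methoxy group, a chlorine or an amine on this phenyl would move the number further from that of compound 1. A single concentration also leaves open whether these steps would hold as differences in potency.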